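The compounds below may be only part of what the source reports. "The series", "measured", "known", "first", "only" and "open" are said of these compounds alone.

Measured in an ADME assay on microsomes from liver (Homo sapiens) for metabolic stability, read by LC-MS, with a stated time of 40 min, tested at 0.5 uM; a higher number here means faster removal of the compound, a lower number slower removal:
compound 1 `CC(C)(CO)Nc1ccc(C(=O)Nc2cccc(S(=O)(=O)NC3CCCC3)n2)c(N2CCC3(CC2)CC3)c1` gives > 399 mL.min-1.g-1, a limit of the assay.
compound 2 `CC(C)(C)NS(=O)(=O)c1cccc(NC(=O)c2ncc(NC(C)(C)CO)nc2N2CCC3(CC2)CC3)c1` gives 74 mL.min-1.g-1.

Compound 1 stands at the limit of > 399 mL.min-1.g-1 in this assay, at which 1 of the 2 values shown sits, so only a limit is known for it, not a number. Compound 3 `CC(C)(C)NS(=O)(=O)c1cccc(NC(=O)c2ccc(NC(C)(C)CO)cc2N2CCC3(CC2)CC3)n1` differs from compound 1 by tert-butyl in place of cyclopentyl on a sulfonamide nitrogen. Among the measured compounds shown here, no measured pair covers this change. For the measured compounds named here, compound 2 carries tert-butyl on a sulfonamide nitrogen as well, but its core differs from that of compound 1, and its value gives no step. The expected step of an at least 1.3-fold lower number from compound 1 to compound 3 (0.12 log units; that floor lies within the scatter) is small, within the usual scatter, with no clear direction. For compound 3 the estimate in this assay is 300 mL.min-1.g-1, within 120 mL.min-1.g-1 to 600 mL.min-1.g-1.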

Compound 3, intrinsic clearance in microsomes: 189 mL.min-1.g-1
Estimate against measurement, compound 3: 1.6-fold (0.20 log units) above; low and high end bracket the measured number.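

In this assay, tert-butyl in place of cyclopentyl on a sulfonamide nitrogen gives an at least 2.1-fold lower number from compound 1 to compound 3 (0.32 log units; beyond the scatter), so a change at this nitrogen alone shifts the read-out beyond the scatter, which compound 2 could not show. The number for compound 1 is a limit, so the step is a floor and its true size is unknown: the limit of > 399 mL.min-1.g-1 in this assay, at which 1 of the 3 values shown sits.

Still open, as far as these compounds go, is whether the step carries over to the core of compound 2. Also open, from the compounds shown here alone, is how a cyclopropyl group or a hydroxyethyl chain on the same nitrogen would read.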